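A few compounds are considered here, and "the series" means these few. Any claim that something is new, unique, unknown or untested is made for them only; others in the source may bear on it.

Compound 1 `O=C(NO)c1ccc(NCc2nc(-c3ccccc3)nn2-c2ccccc2Cl)cc1` gives 64.6% in an assay on Sf9 cells for inhibition of protein deacetylase HDAC6 (Homo sapiens), read by fluorescence, with a stated time of 40 min, tested at 100 nM; a lower number here means less inhibition, a higher number more inhibition at the concentration tested (going by the name of the read-out). Compound 2 `CCc1ccc(-n2nc(-c3ccccc3)nc2CNc2ccc(C(=O)NO)cc2)cc1` gives 38.3% in this assay. Compound 3 `Cc1ccc(-n2nc(-c3ccccc3)nc2CNc2ccc(C(=O)NO)cc2)cc1` gives 60.7% in this assay.

On these three numbers compound 3 stands second highest. Its nearest neighbour is compound 1, which sits above it by a number 3.9 percentage points lower from compound 1 to compound 3 (within the scatter) read the other way, a gap within the scatter; its furthest is compound 2, and the step of a number 22.4 percentage points higher from compound 2 to compound 3 (beyond the scatter) lies beyond the scatter and is modest in size.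

Compound 4 `COc1ccc(-n2nc(-c3ccccc3)nc2CNc2ccc(C(=O)NO)cc2)cc1` is the compound not yet measured. It differs from compound 3 by methoxy in place of methyl on an aromatic carbon.

Among the measured compounds shown here, two measured steps bear on this change, both touching the same phenyl ring on the aromatic nitrogen. The step of a number 3.9 percentage points lower from compound 1 to compound 3 (within the scatter) is within the scatter, while the step of a number 22.4 percentage points higher from compound 2 to compound 3 (beyond the scatter) shows that one more carbon at that position costs a modest amount. For the measured compounds named here, no measured step exchanges methyl for methoxy, so the direction is open. Given that compound 3 lost nothing against compound 1 in a number 3.9 percentage points lower from compound 1 to compound 3 (within the scatter) and gained modestly over compound 2 in a number 22.4 percentage points higher from compound 2 to compound 3 (beyond the scatter), the step of a number 6.7 percentage points lower from compound 3 to compound 4 (within the scatter) is expected to be small, most likely none beyond the scatter. Compound 4 is therefore estimated at 54% in this assay, within a range of 32% to 72%.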

Compound 4, a percentage reported as inhibition, at one concentration (the size of the read-out at that concentration, not a potency): 63.4%
The estimate for compound 4 lay 9.4 percentage points below the measured number; the range from low to high includes it.
By their numbers in this assay, from the lowest: compound 2; then compounds 3, 4 and 1 (each within the scatter of the next).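

In this assay, among the compounds shown here, the exchange of methyl for methoxy on the aromatic carbon para to a large group gives a number 2.7 percentage points higher from compound 3 to compound 4 (within the scatter), the first direct reading of this change, and it shows that the oxygen and the added hydrogen-bond acceptor leave the number unmoved here. Exchanging ethyl for methoxy at the same place gives a number 25.1 percentage points higher from compound 2 to compound 4 (beyond the scatter), so a substituent larger than methyl does not by itself bring the number down, and among these compounds only the ethyl group stands apart. The 4-methoxyphenyl group also matches the 2-chlorophenyl group on the aromatic nitrogen, with a number 1.2 percentage points lower from compound 1 to compound 4 (within the scatter), which leaves methyl, methoxy and the 2-chlorophenyl variant all at one level, with the 4-ethylphenyl compound as the single exception.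

Nothing available here accounts for the low number of the ethyl compound or for the level shared by the others. The compounds shown leave open how an amine, a carboxylic acid or a longer chain such as propyl or ethoxy would read at this place on the ring.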